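Changing the Group on Sulfur in Compound 2

The compounds below may be only part of what the source reports. "The series", "measured", "known", "first", "only" and "open" are said of these compounds alone.

In a physicochemical assay for lipophilicity (on this read-out higher numbers stand for higher lipophilicity and lower numbers for lower lipophilicity), compound 1 (`CCCCCCN(CCCCCSc1nc2c([nH]1)CCCC2)C(=O)Nc1ccc(F)cc1F`) gives 6.81 while compound 2 (`CCCCCCCN(CCCCCSc1nc(O)c2ccccc2n1)C(=O)Nc1ccc(F)cc1F`) gives 6.17 and so holds the lower of the two numbers, by a gap beyond the usual scatter. Compound 3 (`CCCCCCCN(CCCCCSc1ncccn1)C(=O)Nc1ccc(F)cc1F`) is still unmeasured. It differs from compound 2 on a sulfur, where pyrimidin-2-yl stands in place of 4-hydroxyquinazolin-2-yl (pyrimidin-2-yl in place of 4-hydroxyquinazolin-2-yl on a sulfur). Going by the values given here, no measured pair shows this kind of change, so the forecast is loose. A modest downward move is expected, an estimated a number 0.37 log units lower from compound 2 to compound 3 (beyond the scatter) that lies just beyond the scatter. Compound 3 is estimated at 5.8 with an expected range from 5.2 to 6.4 in this assay once measured.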

Compound 3, partition coefficient: 5.41
The estimate for compound 3 lay 0.39 log units above the measured number; the range from low to high includes it.
By their numbers in this assay, from the lowest: compound 3; then compound 2; then compound 1.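

In this assay, the group on the sulfur is shown to matter: putting pyrimidin-2-yl in place of 4-hydroxyquinazolin-2-yl gives a number 0.76 log units lower from compound 2 to compound 3 (beyond the scatter), the first step read at this position. The entering group is the smaller one, with fewer heavy atoms than the group that leaves, and has no hydrogen-bond donor. Nothing available explains the step. The hydroxy group and the all-carbon ring leave together, so their shares cannot be separated. On these data alone, how a phenyl group or an aminopyrimidine on the sulfur would compare remains open.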